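Dropping a Large Side Group from a Weak Inhibitor

This account rests on a few compounds, and the source may have more. Where it says the series, first, only, none or still open, it means among the compounds named here.

Three compounds share a core and were tested in a functional assay on PC-9 cells (Homo sapiens) for inhibition, read by MTT assay, with a stated time of 72 h; a lower number here means a stronger inhibitor, a higher number a weaker inhibitor. Compound 1, `Cc1cc(Nc2cc(-c3ccccc3)[nH]n2)n2nc(SCc3ccc([N+](=O)[O-])cc3)nc2n1`, gives 7980 nM. Compound 2, `Cc1cc(Nc2ccn(Cc3csc4ccc(Cl)cc34)n2)n2nc(SCc3ccc(Br)cc3)nc2n1`, gives 4350 nM, and compound 3, `Cc1cc(Nc2cc(-c3ccc(F)cc3)[nH]n2)n2nc(SCc3ccc(Br)cc3)nc2n1`, gives 6210 nM. Compound 1 has the highest of the three numbers, yet its gaps to compound 3 and to compound 2 both lie within the usual scatter, so none of the three can be called stronger or weaker than the others; all three sit in the same weak range.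

Compound 4, `Cc1cc(Nc2cc(-c3ccccc3)[nH]n2)n2ncnc2n1`, is the untested compound and differs from compound 1 in one place: hydrogen in place of (4-nitrobenzyl)sulfanyl on an aromatic carbon. The group that leaves is large, and it sits on the core, on an aromatic carbon of a five-membered aromatic ring with 3 nitrogen, between two ring nitrogen atoms. Going by the values given here, no step between measured compounds shows what removing a group of this size at this place does, so the direction rests on the fact that compound 1 is already weak at 7980 nM and that stripping away most of one side of the molecule usually costs activity rather than adds it. The step of a 2.5-fold higher number from compound 1 to compound 4 (0.40 log units; beyond the scatter) is expected to weaken the inhibitor beyond the scatter. Compound 4 is therefore estimated at 20000 nM, within a range from 6000 nM to 70000 nM, with a real chance that this assay reports only a limit rather than a number.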

Compound 4, half-maximal inhibitory concentration: > 50000 nM
Compound 4 gave a limit, no number; the forecaster's own chance of this, stated with the estimate: 35%; at least 2.5-fold (0.39 log units) between middle value and limit.
By their numbers in this assay, from the lowest: compounds 2, 3 and 1 (each within the scatter of the next). At a limit, above all of these: compound 4.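

Replacing (4-nitrobenzyl)sulfanyl with hydrogen on the aromatic carbon between two ring nitrogen atoms gives an at least 6.2-fold higher number from compound 1 to compound 4 (0.79 log units; beyond the scatter) in this assay. All three earlier compounds carry a large sulfanyl group at this place, so they could not show what happens without one; this pair shows that the measurable inhibition of compound 1 goes with having that group on the core. The step is only a minimum, since compound 4 reached a limit of the assay and gave no number: the limit of > 50000 nM in this assay, at which 1 of the 4 values shown sits.

The compounds shown leave open which part of the departing group matters: the sulfur, the benzyl ring or the nitro group. A smaller methylsulfanyl group or an amine at this place would help to separate these parts.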